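Changing the Group on the Amine Nitrogen of Compound 1

The source may hold more compounds than are shown below. What is called first, only, known or untested is meant among the compounds shown, and "the series" means these compounds.

Compound 1, `COc1ccc(NCC(=O)Oc2ccc3c(C)cc(=O)oc3c2)cc1`, was tested in a functional assay on the whole organism (strain Wistar albino) for inhibition, with Rattus norvegicus as the target, read by paw edema, with stated times of 30 min and 2 h, at a dose of 20 mg/kg by the oral route (a lower number here means less inhibition, a higher number more inhibition at the dose given (going by the name of the read-out)), where compound 1 gives 33.3%, the lowest of the two numbers shown, though its gap to compound 2 is within the scatter. Compound 2, `Cc1cc(=O)oc2cc(OC(=O)CNc3nccs3)ccc12`, gives 37.1% in this assay. For the measured compounds named here, the one measured step that bears on the present change is a number 3.8 percentage points higher from compound 1 to compound 2 (within the scatter). Compound 3, `Cc1cc(=O)oc2cc(OC(=O)CNN3C=NNC3)ccc12`, differs from compound 1 by a group of 5 heavy atoms (2 carbon, 3 nitrogen; one five-membered non-aromatic ring with 3 hetero atoms) in place of a group of 8 heavy atoms (7 carbon, 1 oxygen; one six-membered aromatic ring of carbon only), on an amine nitrogen. Because a number 3.8 percentage points higher from compound 1 to compound 2 (within the scatter) stayed within the scatter, no step beyond the scatter is expected here either. Compound 3 is therefore estimated at 35%, with a range of 22% to 48%, an expected step of a number 1.7 percentage points higher from compound 1 to compound 3 (within the scatter).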

Compound 3, a percentage reported as inhibition, in the whole organism at one dose (the size of the read-out at that dose, not a potency): 42.3%
Estimate against measurement, compound 3: 7.3 percentage points below, within the range that was stated.
By their numbers in this assay, from the lowest: compounds 1, 2 and 3 (each within the scatter of the next).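

In this assay the new ring on the amine nitrogen gives a number 9 percentage points higher from compound 1 to compound 3 (within the scatter) and a number 5.2 percentage points higher from compound 2 to compound 3 (within the scatter). This position has thus carried a six-membered aromatic ring, a five-membered aromatic ring and now a five-membered non-aromatic ring, with no step beyond the scatter among the three compounds. No measurement shown here accounts for these numbers. Still open, on these data alone, is whether a morpholine ring, a carboxylic acid or a longer chain on this nitrogen would give a step beyond the scatter.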